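Pyridinyl for Fluorophenyl on a Dithiocarbamate Piperazine

The source may report more compounds than this note shows. Statements on the series, on what has been measured and on what is new or still open speak of the compounds shown alone.

Three compounds share a core in which a benzamide bearing an aminophenyl group is joined through a thioether to a dithiocarbamate. In a functional assay on MGC-803 cells (Homo sapiens) for antiproliferative activity, read by CCK-8 assay, with a stated time of 72 h, tested at 2 uM (on this read-out higher numbers stand for a stronger effect at the one concentration tested and lower numbers for a weaker effect), compound 1, `Nc1ccccc1NC(=O)c1ccc(CSC(=S)N2CCN(C(c3ccccc3)c3ccccc3)CC2)cc1`, gives 9.8%; compound 3, `Nc1ccccc1NC(=O)c1ccc(CSC(=S)N(Cc2ccccc2)Cc2ccccc2)cc1`, gives 11%; and compound 2, `Nc1ccccc1NC(=O)c1ccc(CSC(=S)N2CCN(c3ccc(F)cc3)CC2)cc1`, gives 18.8%. Compound 2 thus holds the highest of the three numbers, yet both other values lie within the scatter of it, so no order among the three can be read from these measurements.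

Compound 4, `Nc1ccccc1NC(=O)c1ccc(CSC(=S)N2CCN(c3ccncc3)CC2)cc1`, has not yet been measured. Its structure differs from compound 2 in one place: pyridin-4-yl in place of 4-fluorophenyl on an amine nitrogen in a ring. For the measured compounds named here, no pair of measured compounds shows this particular change, so its effect on this assay is unknown. Given that all three measured values sit so close together, no step beyond the scatter is expected from compound 2 to compound 4, in either direction. The estimated step of a number 1.8 percentage points lower from compound 2 to compound 4 (within the scatter) expresses this expectation. Compound 4 is therefore expected to give about 17%, with a range from 5% to 30%.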

Compound 4, a percentage reported as inhibition, at one concentration (the size of the read-out at that concentration, not a potency): 64.8%
The estimate for compound 4 lay 47.8 percentage points below the measured number; the whole stated range lies below it.
By their numbers in this assay, from the lowest: compounds 1, 3 and 2 (each within the scatter of the next); then compound 4.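

In this assay, for the compounds shown here, pyridin-4-yl in place of 4-fluorophenyl on an amine nitrogen in a ring gives a number 46 percentage points higher from compound 2 to compound 4 (beyond the scatter), the only step in this set that lies beyond the scatter. It shows that this position on the ring with 2 nitrogen can strongly change the read-out, and that a single exchange of one six-membered aromatic ring for another is enough to do so. The exchange brings in 1 hetero atom and 1 hydrogen-bond acceptor, but no measurement here explains the size of the step.

The compounds shown leave open whether the step belongs to the ring nitrogen or to the departure of the fluorine, a question that an unsubstituted phenyl would address. They also leave open whether pyridin-3-yl or pyridin-2-yl at this position would give a similar result.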